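The source may report more compounds than this note shows. Statements on the series, on what has been measured and on what is new or still open speak of the compounds shown alone.

Of the compounds shown here, three on a shared core have been measured so far in a functional assay on MDA-MB-436 cells (Homo sapiens) for antiproliferative activity, read by MTT assay, with a stated time of 48 h; on this read-out higher numbers stand for weaker inhibition and lower numbers for stronger inhibition. Compound 1 (`CN1CCN(c2ccc(-c3cc4c(N5CCN(S(=O)(=O)/C=C/c6ccccc6)CC5)ncnc4s3)cc2)CC1`) gives 8670 nM. Compound 2 (`CN1CCN(c2ccc(-c3cc4c(N5CCN(S(=O)(=O)N6CCCCC6)CC5)ncnc4s3)cc2)CC1`) gives 7570 nM, and a 1.1-fold lower number from compound 1 to compound 2 (0.06 log units; within the scatter) shows that exchanging one sulfonyl substituent for the other does not separate them. Compound 3 (`COc1ccc(NC(=O)N2CCN(c3ncnc4sc(-c5ccc(N6CCN(C)CC6)cc5)cc34)CC2)cc1`) gives 30100 nM, the highest number of the three and the weakest inhibition in this assay, with a 3.5-fold higher number from compound 1 to compound 3 (0.54 log units; beyond the scatter) and a 4.0-fold higher number from compound 2 to compound 3 (0.60 log units; beyond the scatter).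

Compound 4 (`CN1CCN(c2ccc(-c3cc4c(N5CCN(C(=O)Nc6ccc(Cl)c(C(F)(F)F)c6)CC5)ncnc4s3)cc2)CC1`) differs from compound 3 only in the aryl group: 4-chloro-3-(trifluoromethyl)phenyl in place of 4-methoxyphenyl on an amide-type nitrogen, with 4-chloro-3-(trifluoromethyl)phenyl in place of 4-methoxyphenyl on an amide-type nitrogen. Among the compounds with values here, no measured step changes this group alone, so there is no direct precedent. The nearest evidence is the replacement of the whole substituent on the ring nitrogen, and those steps are modest, at a 3.5-fold higher number from compound 1 to compound 3 (0.54 log units; beyond the scatter) and a 4.0-fold higher number from compound 2 to compound 3 (0.60 log units; beyond the scatter). Compound 3 sits at the top of the measured values at 30100 nM, so a modest move toward a lower number is expected, though the direction remains tentative. The expected change is a 2.5-fold lower number from compound 3 to compound 4 (0.40 log units; beyond the scatter). Compound 4 is estimated at 12000 nM, with an expected range of 4000 nM to 35000 nM.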

Compound 4, half-maximal inhibitory concentration: 3500 nM
For compound 4 the middle estimate is 3.4-fold (0.54 log units) above the measured one; measured number below the stated range.
By their numbers in this assay, from the lowest: compound 4; then compounds 2 and 1 (each within the scatter of the next); then compound 3.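

The aryl group on the amide-type nitrogen is now shown to matter on its own: with the rest of compound 3 unchanged, 4-chloro-3-(trifluoromethyl)phenyl in place of 4-methoxyphenyl gives an 8.6-fold lower number from compound 3 to compound 4 (0.93 log units; beyond the scatter) in this assay. The carbamoyl-linked compounds therefore do not all read weaker than the sulfonyl compounds: compound 3 stood above both, whereas compound 4 at 3500 nM has the lowest number of the four, against compound 2 at 7570 nM and compound 1 at 8670 nM. Nothing in the data at hand bears on the reason for this step.

The chlorine and the trifluoromethyl enter together while the methoxy leaves in the same step, so the share of each remains unresolved, and a phenyl carrying only the chlorine or only the trifluoromethyl would be needed to separate them. Also open, as far as these compounds go, is how a nitrile on the phenyl ring, or a saturated cyclohexyl ring in place of the aryl group, would read in this assay.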